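The source may report more compounds than this note shows. Statements on the series, on what has been measured and on what is new or still open speak of the compounds shown alone.

Compound 1, `CCCSc1nc(Cl)c2c(n1)N(Cc1ccccc1)C(C(=O)NCCNC(=O)OC(C)(C)C)N2`, carries a 2-((tert-butoxycarbonyl)amino)ethyl group on an amide-type nitrogen of the shared core. In a functional assay on PC-3 cells (Homo sapiens) for antiproliferative activity, read by MTT assay, with a stated time of 72 h (a higher number here means a weaker inhibitor, a lower number a stronger inhibitor), compound 1 gives 29700 nM. Compound 2, `CCCSc1nc(Cl)c2c(n1)N(Cc1ccccc1)C(C(=O)Nc1ccccc1)N2`, has a plain phenyl on that same nitrogen instead. In this assay compound 2 reaches only > 64000 nM, which is a limit of the assay rather than a measured number. The change from compound 1 to compound 2 therefore reads as an at least 2.1-fold higher number from compound 1 to compound 2 (0.33 log units; beyond the scatter), a loss of potency that is at least modest, with the exact size hidden because compound 2 sits at the limit of > 64000 nM in this assay, at which 1 of the 2 values shown sits.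

Compound 3, `CCCSc1nc(Cl)c2c(n1)N(Cc1ccccc1)C(C(=O)NCCCc1ccccc1)N2`, is the next step: 3-phenylpropyl in place of phenyl on an amide-type nitrogen. This moves the aromatic ring away from the amide nitrogen on a short carbon chain, a shape that shares something with the flexible chain of compound 1 while keeping the phenyl of compound 2. For the measured compounds named here, only the single step from compound 1 to compound 2 bears on it, and it ran toward weaker inhibition. The estimated step from compound 2 to compound 3 is an at least 1.6-fold lower number from compound 2 to compound 3 (0.20 log units; that floor lies within the scatter), expected to recover part of what compound 1 showed at 29700 nM. Compound 3 is therefore estimated at 40000 nM, with a likely range from 15000 nM to 100000 nM.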

Compound 3, half-maximal inhibitory concentration: 12700 nM
The estimate for compound 3 lay 3.1-fold (0.50 log units) above the measured number, outside the stated range (below it).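

In this assay, 3-phenylpropyl in place of phenyl on an amide-type nitrogen gives an at least 5.0-fold lower number from compound 2 to compound 3 (0.70 log units; beyond the scatter), so a six-membered aromatic ring of carbon only on this nitrogen is compatible with measurable activity once a carbon chain is added in front of the ring. That size is only a floor, and compound 2 has a limit of the assay rather than a true number: the limit of > 64000 nM in this assay, at which 1 of the 3 values shown sits. Benzyl in place of (tert-butoxycarbonyl)amino on a saturated chain carbon, two bonds along the chain from an amide-type nitrogen, gives a 2.3-fold lower number from compound 1 to compound 3 (0.37 log units; beyond the scatter), which shows that the (tert-butoxycarbonyl)amino group is not required for activity at this position and that a plain aromatic ring can replace it with a gain.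

As far as these compounds go, how 2-phenylethyl or 4-phenylbutyl on that nitrogen would compare remains open, so these compounds cannot tell whether activity keeps changing with chain length or peaks at a particular one. Also open, from the compounds shown here alone, is what a free primary amine at the end of the chain would do, or a carboxylic acid there.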